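A few compounds are considered here, and "the series" means these few. Any claim that something is new, unique, unknown or untested is made for them only; others in the source may bear on it.

Working notes on the group carried on the sulfur of the shared core, read in a toxicity assay on GES1 cells (Homo sapiens) for inhibition, read by MTT assay, with a stated time of 72 h; a higher number here means a weaker inhibitor, a lower number a stronger inhibitor. Compound 1 `Cc1cc(N2CC[C@@H](C)[C@@H](N(C)c3ncnc4[nH]ccc34)C2)n2nc(SCC3CCCCC3)nc2n1` gives 98200 nM. Compound 2 `Cc1cc(N2CC[C@@H](C)[C@@H](N(C)c3ncnc4[nH]ccc34)C2)n2nc(SCc3ccc(F)c(Cl)c3)nc2n1` returns only a limit of the assay, > 100000 nM. Compound 3 `Cc1cc(N2CC[C@@H](C)[C@@H](N(C)c3ncnc4[nH]ccc34)C2)n2nc(SCc3cc(Cl)ccc3Cl)nc2n1` gives 87500 nM, level with compound 1 within the scatter. Next is compound 4 `COc1ccc(CSc2nc3nc(C)cc(N4CC[C@@H](C)[C@@H](N(C)c5ncnc6[nH]ccc56)C4)n3n2)cc1`, with 4-methoxyphenyl in place of 2,5-dichlorophenyl on a saturated chain carbon bound to a sulfur. The three measured changes at this place bear on it: an at least 1.0-fold higher number from compound 1 to compound 2 (0.00 log units; that floor lies within the scatter), a 1.1-fold lower number from compound 1 to compound 3 (0.05 log units; within the scatter) and an at least 1.1-fold lower number from compound 2 to compound 3 (0.05 log units; that floor lies within the scatter). Two of these are only floors, and none goes beyond the scatter. In this assay, the expected change is therefore none beyond the scatter, an expected 1.0-fold higher number from compound 3 to compound 4 (0.01 log units; within the scatter). Compound 4 is estimated at 90000 nM, with an expected range of 50000 nM to 140000 nM.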

Compound 4, half-maximal inhibitory concentration: > 100000 nM
Compound 4 was reported as a limit; the forecaster's own chance of this, stated with the estimate: 35%; middle value at least 1.1-fold (0.04 log units) from the limit.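

In this assay compound 4 returns only a limit of the assay, and the step between compound 2 and compound 4 cannot be read. The readable steps are an at least 1.1-fold higher number from compound 3 to compound 4 (0.05 log units; that floor lies within the scatter) and an at least 1.0-fold higher number from compound 1 to compound 4 (0.00 log units; that floor lies within the scatter); both are floors, so 4-methoxyphenyl, the first group here with a hydrogen-bond acceptor, adds no step shown beyond the scatter. The top of the range now holds compound 2 and compound 4: the limit of > 100000 nM in this assay, at which 2 of the 4 values shown sit.

Open, going by these compounds, is whether an amine or a carboxylic acid on the saturated chain carbon bound to the sulfur would give a step beyond the scatter in this assay.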